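The compounds below may be only part of what the source reports. "The series", "measured", "known", "first", "only" and "open" are said of these compounds alone.

Measured values in a functional assay on Ehrlich cells (Mus musculus) for antiproliferative activity, read by trypan blue exclusion, with a stated time of 2 h, tested at 10 ug/mL; on this read-out lower numbers stand for a weaker effect and higher numbers for a stronger effect at the one concentration tested:

compound 1 `N#CC1=C(N)N(c2ccc(S(N)(=O)=O)cc2)C2=C(C(=O)CCC2)C1c1ccc(O)cc1`: 90%
compound 2 `N#CC1=C(N)N(c2ccc(S(N)(=O)=O)cc2)C2=C(C(=O)CCC2)C1/C=C/c1ccccc1`: 2%
compound 3 `COc1ccc(C2C(C#N)=C(N)N(c3ccc(S(N)(=O)=O)cc3)C3=C2C(=O)CCC3)cc1`: 30%

Compound 3 stands second highest of the three numbers in this assay. Its nearest neighbour is compound 2, reached by a number 28 percentage points higher from compound 2 to compound 3 (beyond the scatter); its furthest is compound 1, from which it is separated by a number 60 percentage points lower from compound 1 to compound 3 (beyond the scatter).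

Compound 4 `N#CC1=C(N)N(c2ccc(S(N)(=O)=O)cc2)C2=C(C(=O)CCC2)C1c1ccco1` is not yet measured. It differs from compound 3 in one place: furan-2-yl in place of 4-methoxyphenyl on a saturated ring carbon.

Among the measured compounds shown here, two measured steps bear on this change. Both swaps of the group on the saturated ring carbon gave large effects in this assay: a number 88 percentage points lower from compound 1 to compound 2 (beyond the scatter) and a number 28 percentage points higher from compound 2 to compound 3 (beyond the scatter). The change from compound 1 to compound 3, a methyl in place of hydrogen on an oxygen on an aromatic ring, was also large, a number 60 percentage points lower from compound 1 to compound 3 (beyond the scatter). So this position is sensitive, but the three measured groups give no ordering that transfers to furan-2-yl, which is smaller than 4-methoxyphenyl and carries one hydrogen-bond acceptor like it. No direction can be read from these steps with confidence. The step is therefore estimated as no change at the digits printed from compound 3 to compound 4 (within the scatter), with a wide range around it. Compound 4 is estimated at 30%, between 5% and 65%.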

Compound 4, a percentage reported as activity, at one concentration (the size of the read-out at that concentration, not a potency): 0%
Beside the measured number, compound 4's estimate is 30 percentage points above it; measured number outside the range, below it.
By their numbers in this assay, from the lowest: compounds 4 and 2 (each within the scatter of the next); then compound 3; then compound 1.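

In this assay, furan-2-yl in place of 4-methoxyphenyl gives a number 30 percentage points lower from compound 3 to compound 4 (beyond the scatter), so keeping one hydrogen-bond acceptor in an aromatic ring on the saturated ring carbon does not keep the read-out of the larger six-membered ring. The comparison with 2-phenylethenyl gives a number 2 percentage points lower from compound 2 to compound 4 (within the scatter), and the comparison with 4-hydroxyphenyl gives a number 90 percentage points lower from compound 1 to compound 4 (beyond the scatter), which shows that an aromatic ring directly on this carbon is not sufficient for a high read-out, since compound 4 carries one and compound 2 does not. No measurement on these compounds accounts for these differences.

Still open, from the compounds shown here alone, is where an unsubstituted phenyl or a thiophen-2-yl would fall in this assay, which would help separate the effect of ring size from that of the substituent on the ring. A 4-aminophenyl would also test whether the high value of compound 1 is specific to the hydroxyl group, and the single concentration tested leaves the potency of all these compounds undefined.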